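This account rests on a few compounds, and the source may have more. Where it says the series, first, only, none or still open, it means among the compounds named here.

Measured in a functional assay on PC-3 cells (Homo sapiens) for cytotoxicity, read by WST assay, with a stated time of 48 h; on this read-out lower numbers stand for stronger inhibition and higher numbers for weaker inhibition:
- compound 1 `COc1ccc2[nH]cc(/C=C(\C#N)C(=O)c3c[nH]c4ccccc34)c2c1`: 30500 nM
- compound 2 `N#C/C(=C\c1c[nH]c2ccc(Br)cc12)C(=O)c1c[nH]c2ccc(Br)cc12`: > 50000 nM
- compound 3 `COc1ccc2[nH]cc(/C=C(\C#N)C(=O)c3c[nH]c4ccc(OC)cc34)c2c1`: > 50000 nM

Within the data shown here, compound 1 holds the only actual number, at 30500 nM. Compound 2 gives > 50000 nM, which is a limit of the assay. Compound 3 gives > 50000 nM, which is also a limit. The data are therefore bounded by the limit of > 50000 nM in this assay, at which 2 of the 3 values shown sit.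

Compound 4 `COc1ccc2[nH]cc(/C=C(\C#N)C(=O)c3c[nH]c4cc(F)ccc34)c2c1` differs from compound 1 by fluoro in place of hydrogen on an aromatic carbon of a six-membered aromatic ring of carbon only, part of a fused or bridged system of two rings, meta to a fused ring and para to a fused ring.

Among the measured compounds shown here, only one measured step changes a single place, and it too replaces hydrogen on an aromatic carbon, though with methoxy: an at least 1.6-fold higher number from compound 1 to compound 3 (0.21 log units; that floor lies within the scatter). That step is a floor within the scatter, and no measured single change introduces fluoro, so it gives no firm direction for this assay. The expected change is therefore none beyond the scatter, and a limit remains possible. The expected step is a 1.0-fold lower number from compound 1 to compound 4 (0.01 log units; within the scatter). For compound 4 the estimate is 30000 nM, with an expected range from 12000 nM to 50000 nM.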

Compound 4, half-maximal inhibitory concentration: > 50000 nM
Compound 4 ended at the assay's limit; the forecaster's own chance of this, stated with the estimate: 30%; at least 1.6-fold (0.22 log units) between middle value and limit.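

In this assay, fluoro in place of hydrogen, on an aromatic carbon meta to a fused ring and para to a fused ring, gives an at least 1.6-fold higher number from compound 1 to compound 4 (0.21 log units; that floor lies within the scatter). This is a second single change on compound 1, after methoxy, that yields no lower number, here with an entering group of only 1 heavy atom and no hydrogen-bond donors or acceptors. The result for compound 4 is a limit and not a number, so the size of the step stays unread and no loss beyond the scatter can be claimed: the limit of > 50000 nM in this assay, at which 3 of the 4 values shown sit.

Open is whether any replacement of hydrogen at this carbon moves the read-out beyond the scatter in either direction, given that fluoro is the only group shown there. A chloro group, an amine or a carboxylic acid at the same carbon would test this, and changes elsewhere on the core of compound 1 could show whether the series can move well clear of the limit.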